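The compounds below may be only part of what the source reports. "The series", "measured", "known", "first", "only" and "open" are said of these compounds alone.

Measured so far in a functional assay on cells (Tumor Cell line, Homo sapiens) for cytotoxicity; on this read-out higher numbers stand for weaker inhibition of growth and lower numbers for stronger inhibition of growth:
- compound 1 `COc1ccc(-c2cc(O)c3cccnc3n2)cc1` gives 38000 nM
- compound 2 `COc1ccc(-c2cc(O)c3c(C)cc(C)nc3n2)cc1` gives 33100 nM

Compound 2 stands at 33100 nM and compound 1 at 38000 nM. These two numbers lie within the usual scatter of each other, so they do not rank the two compounds. Both sit in the same region of the read-out, and no number yet shows a clear separation within the series.

The next compound to be read is compound 3 `COc1ccc(-c2cc(O)c3ccc(C)nc3n2)cc1`, which has no value yet. Relative to compound 2 it carries hydrogen in place of methyl on an aromatic carbon, opposite the ring nitrogen: hydrogen in place of methyl on an aromatic carbon. The core and the rest of the structure stay as they are.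

In this assay no step beyond the scatter is expected, and no direction is favoured. This expectation rests on compound 1 at 38000 nM lying within the scatter of compound 2 at 33100 nM. The expected step is a 1.1-fold higher number from compound 2 to compound 3 (0.04 log units; within the scatter) ( within the scatter ). For compound 3 the estimated value is 36000 nM, with an expected range of 18000 nM to 70000 nM.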

Compound 3, concentration for 50% growth inhibition: 91200 nM
Compound 3: middle estimate off by 2.5-fold (0.40 log units), on the low side; the whole stated range lies below it.
By their numbers in this assay, from the lowest: compounds 2 and 1 (each within the scatter of the next); then compound 3.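

In this assay, for the compounds shown here, the aromatic carbon opposite the ring nitrogen is the first place where a single change moves the read-out beyond the scatter: hydrogen in place of methyl there gives a 2.8-fold higher number from compound 2 to compound 3 (0.44 log units; beyond the scatter) and so weakens inhibition of growth. A methyl on an aromatic carbon has no single direction across these compounds, as methyl in place of hydrogen on the core of compound 1 also goes the same way, with a 2.4-fold higher number from compound 1 to compound 3 (0.38 log units; beyond the scatter), so that compound 3 ends with the weakest inhibition of growth of the three, while both steps stay modest. Nothing measured here accounts for either step, and the reading stops at the numbers themselves.

The compounds shown leave open how a longer chain such as ethyl, a methoxy group or an amine would read on the carbon opposite the ring nitrogen. They also leave open whether any group there would give clearly stronger inhibition of growth than compound 2, which stands at 33100 nM in this assay.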